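A few compounds are considered here, and "the series" means these few. Any claim that something is new, unique, unknown or untested is made for them only; others in the source may bear on it.

The measurements come from a functional assay on BMDM cells (Mus musculus, strain C57BL/6) for inhibition, with a stated time of 2 days; a lower number here means a stronger inhibitor, a higher number a weaker inhibitor. Compound 1, `Cc1csc(NC(=O)Cn2cc(-c3ccc(Cl)cc3)nn2)n1`, gives 520 nM. Compound 3, `CCOC(=O)c1sc(NC(=O)Cn2cc(-c3ccc([N+](=O)[O-])cc3)nn2)nc1C`, gives 1840 nM. Compound 2, `COc1cccc(-c2cn(-c3ccc(C(F)(F)F)cc3)nc2C(=O)N2CCN(c3ncccn3)CC2)c1`, reaches only a limit of this assay, > 30000 nM, so no number is known for it; this is the limit of > 30000 nM in this assay, at which 1 of the 3 values shown sits. Compound 4, `COc1cccc(-c2cn(-c3ccc(C(F)(F)F)cc3)nc2C(=O)NC2CCCCC2)c1`, differs from compound 2 in one place: cyclohexylamino in place of 4-(pyrimidin-2-yl)piperazin-1-yl on a carbonyl carbon. Going by the values given here, no pair of measured compounds shows what this change does, so the size of the step is uncertain. The step from compound 2 to compound 4 is expected to be an at least 1.5-fold lower number from compound 2 to compound 4 (0.17 log units; that floor lies within the scatter), a gain that may still sit within the usual scatter. For compound 4 the estimate is 20000 nM, within 3000 nM to 60000 nM, and a result that is again only a limit would not be surprising.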

Compound 4, half-maximal inhibitory concentration: > 30000 nM
Compound 4: no number, only a limit (the forecaster's own chance of this, stated with the estimate: 50%); middle value at least 1.5-fold (0.17 log units) from the limit.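

Compound 2 and compound 4 each give only a limit in this assay, so the step between them cannot be read: the limit of > 30000 nM in this assay, at which 2 of the 4 values shown sit.

The compounds shown leave open whether cyclohexylamino or 4-(pyrimidin-2-yl)piperazin-1-yl on this carbonyl carbon gives the stronger inhibitor.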